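Adding a methoxycarbonyl to the core of compound 3

The source may hold more compounds than are shown below. What is called first, only, known or untested is meant among the compounds shown, and "the series" means these compounds.

Measured so far:
compound 1, `Oc1ccc(CNc2cc(C(F)(F)F)cc3[nH]ncc23)cc1`: 75%
compound 2, `O=[N+]([O-])c1cccc(CNc2cc(C(F)(F)F)cc3[nH]ncc23)c1`: 60%
compound 3, `O=[N+]([O-])c1ccccc1CNc1cccc2[nH]ncc12`: 45%

All three were tested in an assay for inhibition of Tryptophan 2,3-dioxygenase (Homo sapiens), with stated times of 10 min and 60 min, tested at 10 uM; a lower number here means a weaker effect, a higher number a stronger effect of the compound at the concentration tested. Compound 3 stands lowest of the three numbers: compound 2 is nearest, higher by more than the usual scatter, and compound 1 is furthest, higher still. Going by the values given here, none of these pairs differ in only one place, so no single step has been measured.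

Compound 4, `COC(=O)c1cc(NCc2ccccc2[N+](=O)[O-])c2cn[nH]c2c1`, differs from compound 3 in one place: methoxycarbonyl in place of hydrogen on an aromatic carbon. Nothing measured shows what this change does. In this assay the step of a number 3 percentage points higher from compound 3 to compound 4 (within the scatter) is expected to be small, not clearly beyond the scatter. Compound 4 is therefore estimated at 48%, expected between 28% and 68%.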

Compound 4, a percentage reported as inhibition, at one concentration (the size of the read-out at that concentration, not a potency): 16%
Compound 4: the middle estimate sits 32 percentage points above what was measured; measured number outside the range, below it.
By their numbers in this assay, from the lowest: compound 4; then compound 3; then compound 2; then compound 1.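

In this assay, putting methoxycarbonyl on this aromatic carbon gives a number 29 percentage points lower from compound 3 to compound 4 (beyond the scatter). Going by these compounds alone, this is the first single change measured here, and it shows that this position of the core is not indifferent to substitution, at least for this group on compound 3. Nothing available explains why the number falls.

As far as these compounds go, whether the loss belongs to methoxycarbonyl itself or to any group on this carbon stays open. A carboxylic acid, an amide or a methyl group at the same place would help separate these two readings.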